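The source may report more compounds than this note shows. Statements on the series, on what has been measured and on what is new or still open speak of the compounds shown alone.

Measured so far:
compound 1 `CC1=C(/C=C/C(=O)/C=C/c2ccc(Cl)cc2)C(C)(C)CCC1` — 9500 nM
compound 2 `CC1=C(/C=C/C(=O)/C=C/c2ccc(Cl)c(Cl)c2)C(C)(C)CCC1` — 35500 nM

In a functional assay on PC-3 cells (Homo sapiens) for cytotoxicity, read by sulforhodamine B assay, with a stated time of 48 h (on this read-out higher numbers stand for weaker inhibition and lower numbers for stronger inhibition), compound 1 stands lowest of the two numbers; its nearest neighbour is compound 2, with a 3.7-fold higher number from compound 1 to compound 2 (0.57 log units; beyond the scatter). Compound 3 `CC1=C(/C=C/C(=O)/C=C/c2cccnc2)C(C)(C)CCC1` differs from compound 1 by pyridin-3-yl in place of 4-chlorophenyl on a double-bonded chain carbon bound to a double-bonded chain carbon. Among the measured compounds shown here, no measured step covers such an exchange of the aromatic ring; the only step in hand, a 3.7-fold higher number from compound 1 to compound 2 (0.57 log units; beyond the scatter), concerns an added chloro and does not bear directly on it. A modest shift is therefore expected, most likely towards a higher number, but the direction is uncertain. Compound 3 is expected at 15000 nM, within 5000 nM to 45000 nM. The expected step is a 1.6-fold higher number from compound 1 to compound 3 (0.20 log units; within the scatter).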

Compound 3, half-maximal inhibitory concentration: 10200 nM
Estimate against measurement, compound 3: 1.5-fold (0.17 log units) above; the measured number falls inside the stated range.
By their numbers in this assay, from the lowest: compounds 1 and 3 (each within the scatter of the next); then compound 2.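

In this assay, pyridin-3-yl in place of 4-chlorophenyl on this double-bonded chain carbon gives a 1.1-fold higher number from compound 1 to compound 3 (0.03 log units; within the scatter), so this place accepts a ring with a hetero atom and no chloro without a readable change. Among the compounds shown here, the added chloro remains the only change here with a step beyond the scatter, at a 3.7-fold higher number from compound 1 to compound 2 (0.57 log units; beyond the scatter). No measurement in hand accounts for either result.

Still open, as far as these compounds go, is whether a carboxylic acid or an amine in this place would leave the number of compound 1 at 9500 nM or shift it in either direction.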